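The compounds below may be only part of what the source reports. "The series", "measured", "known", "first", "only" and "open" are said of these compounds alone.

In a functional assay on LNCaP cells (Homo sapiens) for antiproliferative activity, read by propidium iodide staining, with a stated time of 96 h (on this read-out higher numbers stand for weaker inhibition and lower numbers for stronger inhibition), three compounds that share one core have been measured so far. Compound 1 `CC(O)(CS(=O)(=O)c1ccc(S(F)(F)(F)(F)F)cc1)C(=O)Nc1ccc(S(F)(F)(F)(F)F)cc1` gives 29200 nM, compound 2 `CC(O)(CS(=O)(=O)c1ccc(C(F)(F)F)cc1)C(=O)Nc1ccc(S(F)(F)(F)(F)F)cc1` gives 20700 nM, and compound 3 `CC(O)(CS(=O)(=O)c1cccc(C(F)(F)F)c1)C(=O)Nc1ccc(S(F)(F)(F)(F)F)cc1` gives 21000 nM. Compound 3 lies within the usual scatter of both other compounds, so no order can be drawn among them.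

Compound 4 `CC(O)(CS(=O)(=O)c1ccc(OC(F)(F)F)cc1)C(=O)Nc1ccc(S(F)(F)(F)(F)F)cc1` carries 4-(trifluoromethoxy)phenyl in place of 3-(trifluoromethyl)phenyl on a sulfonyl sulfur. Within the data shown here, no measured compound carries this group, so the evidence is indirect. Among the measured compounds shown here, two measured steps bear on the change. Changing the group on an aromatic carbon gave a 1.4-fold lower number from compound 1 to compound 2 (0.15 log units; within the scatter), and placing 3-(trifluoromethyl)phenyl where 4-(trifluoromethyl)phenyl stood gave a 1.0-fold higher number from compound 2 to compound 3 (0.01 log units; within the scatter). Both steps are within the scatter, so no step beyond the scatter is expected in this assay. The expected step is a 1.0-fold higher number from compound 3 to compound 4 (0.02 log units; within the scatter), which would be too small to tell apart from repeat variation. For compound 4 the estimated value is 22000 nM, with an expected range from 12000 nM to 38000 nM.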

Compound 4, half-maximal inhibitory concentration: 92800 nM
Estimate against measurement, compound 4: 4.2-fold (0.63 log units) below, and the stated range ends below it.
By their numbers in this assay, from the lowest: compounds 2, 3 and 1 (each within the scatter of the next); then compound 4.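

In this assay, the group on the sulfonyl sulfur turns out to matter: earlier changes there stayed within the scatter, but trifluoromethoxy in place of trifluoromethyl on the aromatic carbon gives a 4.5-fold higher number from compound 2 to compound 4 (0.65 log units; beyond the scatter). Replacing 3-(trifluoromethyl)phenyl with 4-(trifluoromethoxy)phenyl gives a 4.4-fold higher number from compound 3 to compound 4 (0.65 log units; beyond the scatter), and replacing the group of 6 heavy atoms with trifluoromethoxy gives a 3.2-fold higher number from compound 1 to compound 4 (0.50 log units; beyond the scatter), so the inhibition weakens beyond the scatter in all three comparisons. The entering group adds one oxygen, counted as a hydrogen-bond acceptor, but no measurement here accounts for the weaker inhibition.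

From the compounds shown here alone, it remains open whether a methoxy group or a chlorine atom on this ring would track with trifluoromethoxy or with trifluoromethyl. Going by these compounds, how 3-(trifluoromethoxy)phenyl would compare with 4-(trifluoromethoxy)phenyl also remains open.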